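Piperidine for piperazine on the shared core

The source may report more compounds than this note shows. Statements on the series, on what has been measured and on what is new or still open speak of the compounds shown alone.

Compound 1 `CN1CCC(c2ccc3c(c2)oc(=O)n3C(=O)NCCCCc2ccccc2)CC1=O`: 20000 nM
Compound 2 `CN1CCN(c2ccc3c(c2)oc(=O)n3C(=O)NCCCCc2ccccc2)CC1`: < 1000 nM
Compound 3 `CN1CCC(c2ccc3c(c2)oc(=O)n3C(=O)NCCCCc2ccccc2)CC1`: not yet measured

In a physicochemical assay for solubility, read by HPLC, in phosphate buffer, measured as kinetic solubility, with a stated time of 1 h, at pH 7.4, tested at 250 uM (on this read-out lower numbers stand for lower solubility and higher numbers for higher solubility), compound 2 gives < 1000 nM, which is a limit of the assay and not a number. Compound 3 has 1-methylpiperidin-4-yl in place of 4-methylpiperazin-1-yl on an aromatic carbon. For the measured compounds named here, the only measured step at this place is an at least 20-fold lower number from compound 1 to compound 2 (1.30 log units; beyond the scatter), which is large and beyond the scatter. It swaps 1-methyl-2-oxopiperidin-4-yl for 4-methylpiperazin-1-yl, so the departing group is the same one that compound 3 lacks. A higher number is therefore expected in this assay, by a smaller step than that one. For compound 3 the estimated value is 4000 nM, with an expected range of 1000 nM to 20000 nM. The expected change is an at least 4.0-fold higher number from compound 2 to compound 3 (0.60 log units; beyond the scatter).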

Compound 3, solubility: 120000 nM
Compound 3: the middle estimate sits 30-fold (1.48 log units) below what was measured; the whole stated range lies below it.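

In this assay, the 1-methylpiperidin-4-yl group on this aromatic carbon carries the highest number of the three, with an at least 120-fold higher number from compound 2 to compound 3 (2.07 log units; beyond the scatter) and a 6.0-fold higher number from compound 1 to compound 3 (0.78 log units; beyond the scatter). Compound 2 and compound 3 differ at this place by one ring atom, a carbon in place of a nitrogen. The full size of that step stays unknown because compound 2 gives a limit, not a number: the limit of < 1000 nM in this assay, at which 1 of the 3 values shown sits.

Open, as far as these compounds go, is whether a morpholine or a carboxylic acid at this place would read closer to compound 3 or compound 2. Also open, from the compounds shown here alone, is whether the step holds with a shorter chain on the shared core.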